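Losing one hydroxy in a tightly clustered series

This account rests on a few compounds, and the source may have more. Where it says the series, first, only, none or still open, it means among the compounds named here.

In a functional assay on HepG2 cells (Homo sapiens) for antiproliferative activity (on this read-out higher numbers stand for weaker inhibition and lower numbers for stronger inhibition), compound 1 (`CC[C@H](C)[C@H]1C(=O)N[C@H](Cc2ccc(O)c(Br)c2)C(=O)N[C@@H](C(C)(C)O)C(=O)O[C@H](c2ccccc2)[C@H](C)/C=C/C=C(\C)[C@H](OC)C/C=C(\C)C(=O)N1C`) gives 5.21 nM while compound 2 (`CC[C@H](C)[C@H]1C(=O)N[C@H](Cc2cc(Cl)c(O)c(Cl)c2)C(=O)N[C@@H](C(C)C)C(=O)O[C@H](c2ccccc2)[C@H](C)/C=C/C=C(\C)[C@H](OC)C[C@@H]2O[C@@]2(C)C(=O)N1C`) gives 5.65 nM and compound 3 (`CC[C@H](C)[C@H]1C(=O)N[C@H](Cc2ccc(O)c(Br)c2)C(=O)N[C@@H](C(C)(C)O)C(=O)O[C@H](c2ccccc2)[C@H](C)/C=C/C=C(\C)[C@H](OC)C[C@@H]2O[C@@]2(C)C(=O)N1C`) gives 2.98 nM as measured values. Compound 1 stands within the usual scatter of both others, so these numbers cannot be ranked. Compound 4 (`CC[C@H](C)[C@H]1C(=O)N[C@H](Cc2ccc(O)c(Br)c2)C(=O)N[C@@H](C(C)C)C(=O)O[C@H](c2ccccc2)[C@H](C)/C=C/C=C(\C)[C@H](OC)C/C=C(\C)C(=O)N1C`) is still unmeasured and differs from compound 1 in one place (hydrogen in place of hydroxy on a saturated chain carbon bound to two saturated chain carbons and a saturated ring carbon): hydrogen in place of hydroxy on a saturated chain carbon bound to two saturated chain carbons and a saturated ring carbon. This turns 1-hydroxy-1-methylethyl into isopropyl. Among the measured compounds shown here, no measured pair isolates this change, but compound 2 also carries isopropyl and gives 5.65 nM despite other differences. In this assay no step beyond the scatter is therefore expected, in either direction. The expected change is a 1.0-fold lower number from compound 1 to compound 4 (0.02 log units; within the scatter) and stays within that scatter. For compound 4 the estimate is 5 nM with an expected range from 2 nM to 13 nM as its upper end.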

Compound 4, half-maximal inhibitory concentration: 53.7 nM
For compound 4 the middle estimate is 11-fold (1.03 log units) below the measured one, outside the stated range (above it).
By their numbers in this assay, from the lowest: compounds 3, 1 and 2 (each within the scatter of the next); then compound 4.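

In this assay, the hydroxy on this saturated chain carbon proves to carry real weight: replacing it with hydrogen gives a 10-fold higher number from compound 1 to compound 4 (1.01 log units; beyond the scatter) and weakens inhibition. The earlier compounds shown here lay too close together to reveal any such sensitivity, whereas this pair differs in one place only. Nothing available explains the loss. As far as these compounds go, whether a methoxy or an amine at this position would behave like the hydroxy or like hydrogen remains open. So does whether the same change would have a similar effect on the core of compound 3.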